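The source may hold more compounds than are shown below. What is called first, only, known or untested is meant among the compounds shown, and "the series" means these compounds.

Compound 1 `CCc1ccc(S(=O)(=O)N2CCC(N3CCC(C)CC3)CC2)cc1`: in an ADME assay on HCT-116 cells (Homo sapiens) for cytotoxicity, read by CellTiter-Glo, with a stated time of 72 h (on this read-out higher numbers stand for weaker inhibition and lower numbers for stronger inhibition), compound 1 gives > 5000 nM, a limit of the assay.
Compound 2 `Cc1noc(C)c1S(=O)(=O)N1CCC(N2CCC(C)CC2)CC1`: compound 2 gives > 10000 nM, also a limit.
Compound 3 `CC1CCN(C2CCN(S(=O)(=O)c3ccc(F)cc3F)CC2)CC1`: compound 3 gives > 5000 nM, again a limit.

Compound 3 thus stands at a limit, and the other two values shown are limits too: the limit of > 5000 nM in this assay, at which 2 of the 3 values shown sit, and (the limit of > 10000 nM in this assay, at which 1 of the 3 values shown sits). The change to compound 4 `CC1CCN(C2CCN(S(=O)(=O)c3cccnc3Cl)CC2)CC1` is 2-chloropyridin-3-yl in place of 2,4-difluorophenyl on a sulfonyl sulfur. Three measured steps, all on a sulfonyl sulfur, bear on it: a step that the two limits leave unreadable from compound 1 to compound 2, a step that the two limits leave unreadable from compound 1 to compound 3 and a step that the two limits leave unreadable from compound 2 to compound 3. None of them yields a readable size, so no direction can be drawn from them. Compound 4 is therefore expected to behave like its neighbours in this assay, with no step beyond the scatter, an expected step that the limit leaves unreadable from compound 3 to compound 4. The estimate for compound 4 is 8000 nM, expected between 3000 nM and 30000 nM, most likely reported as a limit.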

Compound 4, half-maximal inhibitory concentration: > 10000 nM
Compound 4 was reported as a limit (the forecaster's own chance of this, stated with the estimate: 80%); middle value at least 1.2-fold (0.09 log units) from the limit.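

Compound 4 also sits at a limit, so its steps from compound 1, compound 2 and compound 3 cannot be read. The compounds shown leave open whether any group on the sulfonyl sulfur changes the read-out in this assay.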